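Trimming the Triazole Arm of Compound 3

The source may report more compounds than this note shows. Statements on the series, on what has been measured and on what is new or still open speak of the compounds shown alone.

For the measured compounds named here, compound 3 `O=C1O[C@H]([C@@H](O)Cn2cc(CNS(=O)(=O)c3ccc(F)cc3)nn2)C(OCc2ccccc2)=C1OCc1ccccc1` is the only compound here with a numeric result: in a functional assay on CFPAC-1 cells (Homo sapiens) for antiproliferative activity, read by MTT assay, with a stated time of 72 h (on this read-out lower numbers stand for stronger inhibition and higher numbers for weaker inhibition), compound 3 gives 34700 nM. Compound 1 `O=C1O/C(=C\Cn2cc(-c3ccc(Br)cc3)nn2)C(OCc2ccccc2)=C1OCc1ccccc1` reaches only a limit of the assay, > 100000 nM, in this assay. Compound 2 `COc1ccc(-c2cn(C/C=C3\OC(=O)C(OCc4ccccc4)=C3OCc3ccccc3)nn2)cc1` likewise reaches only a limit, > 100000 nM. The step that the two limits leave unreadable from compound 1 to compound 2 is therefore unreadable in size, and two of the three results sit at the limit of > 100000 nM in this assay, at which 2 of the 3 values shown sit. Compound 4 `O=C1O[C@H]([C@@H](O)Cn2cc(CCO)nn2)C(OCc2ccccc2)=C1OCc1ccccc1` differs from compound 3 in one place: hydroxymethyl in place of ((4-fluorophenyl)sulfonyl)amino on a saturated chain carbon bound to an aromatic carbon. Going by the values given here, no measured step bears on this change, so no direction can be drawn from the data. Compound 4 is therefore expected close to compound 3, with the step of a 1.2-fold higher number from compound 3 to compound 4 (0.06 log units; within the scatter) estimated to stay within the usual scatter. The estimate for compound 4 in this assay is 40000 nM, between 12000 nM and 130000 nM.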

Compound 4, half-maximal inhibitory concentration: > 100000 nM
Compound 4 gave a limit, no number; the forecaster's own chance of this, stated with the estimate: 40%; middle value at least 2.5-fold (0.39 log units) away from the limit.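

Replacing ((4-fluorophenyl)sulfonyl)amino with hydroxymethyl on a saturated chain carbon bound to an aromatic carbon gives an at least 2.8-fold higher number from compound 3 to compound 4 (0.45 log units; beyond the scatter) in this assay. For the compounds shown here, this is the first readable step here, and it shows that this change at this position is not neutral; its true size remains unknown, since compound 4 reaches only a limit. Compound 3 therefore remains the only compound with a numeric result: the limit of > 100000 nM in this assay, at which 3 of the 4 values shown sit.

From the compounds shown here alone, whether the fluorophenyl ring or the sulfonyl amino link matters more stays open. An amine or a carboxylic acid at this place would help to separate the two.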